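Liver Microsome Stability: From Compound 1 to Compound 4

The source may report more compounds than this note shows. Statements on the series, on what has been measured and on what is new or still open speak of the compounds shown alone.

Compound 1 `CCOc1cc(NC(=O)NCc2cc(C)c(-c3cn(C)nc3C(F)(F)F)nn2)cc(C#N)n1` was examined in an ADME assay on microsomes from liver (Homo sapiens) for metabolic stability, read by LC-MS, with a stated time of 4 h, tested at 1 uM; a lower number here means slower removal, a higher number faster removal of the compound. In this assay compound 1 gives < 28.4 mL/min/kg, which is a limit of the assay rather than a measured number. Compound 2 `COCCOc1cc(NC(=O)NCc2cc(C)c(-c3cn(C)nc3C(F)(F)F)nn2)cc(Cl)n1` differs from compound 1 in more than one place, and in this assay compound 2 gives < 23.4 mL/min/kg, also a limit. Compound 3 `CCOc1nc(C#N)cc(NC(=O)NCc2cc(C)c(-c3cn(C)nc3C(F)(F)F)nn2)c1C` carries a methyl in place of hydrogen on an aromatic carbon relative to compound 1, and in this assay compound 3 gives < 35 mL/min/kg, again a limit. The step that the two limits leave unreadable from compound 1 to compound 3 therefore cannot be sized, as both of its ends are limits. Among the measured compounds shown here, every value shown so far sits at a ceiling (the limit of < 23.4 mL/min/kg in this assay, at which 1 of the 3 values shown sits, (the limit of < 28.4 mL/min/kg in this assay, at which 1 of the 3 values shown sits), (the limit of < 35 mL/min/kg in this assay, at which 1 of the 3 values shown sits)), so no measured step gives a readable size in either direction.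

Compound 4 `CCOc1nc(C)cc(NC(=O)NCc2cc(C)c(-c3cn(C)nc3C(F)(F)F)nn2)c1Cl` is compound 1 with 3-chloro-2-ethoxy-6-methylpyridin-4-yl in place of 2-cyano-6-ethoxypyridin-4-yl on an amide-type nitrogen. For the measured compounds named here, no measured pair covers this exchange, so the expectation rests only on the three compounds all sitting at limits in this assay. The step from compound 1 to compound 4 is expected to be a step that the limit leaves unreadable from compound 1 to compound 4, that is, nothing clearly beyond the scatter. Compound 4 is estimated to give 20 mL/min/kg in this assay, with a range from 8 mL/min/kg to 50 mL/min/kg.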

Compound 4, clearance: < 25 mL/min/kg
Compound 4: only a limit was reported; the forecaster's own chance of this, stated with the estimate: 55%; the middle value lies beyond the limit too.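

In this assay compound 4 gives < 25 mL/min/kg, which is a limit of the assay and not a number. Compound 1 also stands at a limit, so the step between compound 1 and compound 4 cannot be read. The compounds shown leave open how quickly any of them is actually removed, and whether this exchange of groups changes that at all.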